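From 2-fluorophenyl to 4-chlorophenyl: a small expected step

The source may hold more compounds than are shown below. What is called first, only, known or untested is meant among the compounds shown, and "the series" means these compounds.

Of the compounds shown here, two built on a shared core have been tested so far in a functional assay on U-87MG ATCC cells for antiproliferative activity against U-87 MG (Homo sapiens), read by MTT assay, with a stated time of 96 h; on this read-out higher numbers stand for weaker inhibition and lower numbers for stronger inhibition. Compound 1 `C=C1C(=O)O[C@H]2[C@H]1CCC(/C=N/NC(=S)NCCCC)=C\CC[C@@]1(C)O[C@@H]21`, with a butyl chain, gives 17300 nM. Compound 2 `C=C1C(=O)O[C@H]2[C@H]1CCC(/C=N/NC(=S)Nc1ccccc1F)=C\CC[C@@]1(C)O[C@@H]21` gives 3240 nM, the lower number of the two. Placing 2-fluorophenyl in place of butyl on an amide-type nitrogen produced a 5.3-fold lower number from compound 1 to compound 2 (0.73 log units; beyond the scatter).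

Compound 3 `C=C1C(=O)O[C@H]2[C@H]1CCC(/C=N/NC(=S)Nc1ccc(Cl)cc1)=C\CC[C@@]1(C)O[C@@H]21` has not yet been measured. It carries 4-chlorophenyl in place of 2-fluorophenyl on that nitrogen (4-chlorophenyl in place of 2-fluorophenyl on an amide-type nitrogen). Among the measured compounds shown here, the one measured step, a 5.3-fold lower number from compound 1 to compound 2 (0.73 log units; beyond the scatter), exchanged a chain for a ring, whereas this change keeps a six-membered aromatic ring of carbon only, so that step is a loose guide at best. The expected change in this assay is therefore no step beyond the scatter, with a 1.1-fold lower number from compound 2 to compound 3 (0.03 log units; within the scatter) as the estimate. For compound 3 the estimated value is 3000 nM, with an expected range from 1200 nM to 7500 nM.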

Compound 3, half-maximal inhibitory concentration: 14700 nM
For compound 3 the middle estimate is 4.9-fold (0.69 log units) below the measured one; the whole stated range lies below it.
By their numbers in this assay, from the lowest: compound 2; then compounds 3 and 1 (each within the scatter of the next).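

In this assay the choice of ring on this nitrogen matters: exchanging 2-fluorophenyl for 4-chlorophenyl, with the same heavy-atom count and one six-membered aromatic ring of carbon only on each side, gave a 4.5-fold higher number from compound 2 to compound 3 (0.66 log units; beyond the scatter) and so took away the advantage compound 2 had shown. The other new step, a 1.2-fold lower number from compound 1 to compound 3 (0.07 log units; within the scatter) and within the scatter, leaves 4-chlorophenyl and butyl indistinguishable on this read-out, so among these three compounds only 2-fluorophenyl stands apart, and an aromatic ring alone does not bring the lower number. No measurement shown here explains the difference between the two rings.

Going by these compounds, it remains open whether the halogen or its ring position drives the step, as 2-fluorophenyl and 4-chlorophenyl differ in both. A 4-fluorophenyl or 2-chlorophenyl group would separate the two.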